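Swapping a Benzylamine Link for a Thioether

A few compounds are considered here, and "the series" means these few. Any claim that something is new, unique, unknown or untested is made for them only; others in the source may bear on it.

Three compounds share one core and differ only in the group carried on a chain nitrogen. In a functional assay on NCI-H226 cells (Homo sapiens) for inhibition, read by sulforhodamine B assay, with a stated time of 48 h (a higher number here means a weaker inhibitor of growth, a lower number a stronger inhibitor of growth), compound 1 `Nc1cc(N)c2nc(-c3ccccc3)c(NCc3ccc(Cl)c(Cl)c3)nc2c1` gives 46800 nM; compound 2 `COc1ccc(CNc2nc3cc(N)cc(N)c3nc2-c2ccccc2)cc1OC` gives 30900 nM; compound 3 `Nc1cc(N)c2nc(-c3ccccc3)c(NCc3ccc(F)cc3)nc2c1` gives 47900 nM. The steps of a 1.5-fold lower number from compound 1 to compound 2 (0.18 log units; within the scatter), a 1.0-fold higher number from compound 1 to compound 3 (0.01 log units; within the scatter) and a 1.6-fold higher number from compound 2 to compound 3 (0.19 log units; within the scatter) all stay within the scatter, so compound 3 sits at the upper end of three numbers that cannot be told apart. Compound 4 `Nc1cc(N)c2nc(-c3ccccc3)c(Sc3ccc(F)cc3)nc2c1` differs from compound 3 by (4-fluorophenyl)sulfanyl in place of (4-fluorobenzyl)amino on an aromatic carbon. For the measured compounds named here, no measured step touches the link itself; each of them only swaps the ring beyond it, and none moved the number beyond the scatter. Going by these compounds, compound 4 is therefore expected to give 45000 nM, between 12000 nM and 150000 nM, a step of a 1.1-fold lower number from compound 3 to compound 4 (0.03 log units; within the scatter) that is expected to be small, with wide uncertainty because the link change itself is untested.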

Compound 4, concentration for total growth inhibition: 46800 nM
The estimate for compound 4 lay 1.0-fold (0.02 log units) below the measured number, within the range that was stated.
By their numbers in this assay, from the lowest: compounds 2, 1, 4 and 3 (each within the scatter of the next).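

For the compounds shown here, for the first time the link itself changes, not just the ring beyond it: (4-fluorophenyl)sulfanyl in place of (4-fluorobenzyl)amino on this aromatic carbon gives a 1.0-fold lower number from compound 3 to compound 4 (0.01 log units; within the scatter). The group that enters has no hydrogen-bond donor, whereas the group that leaves has one, yet with this 4-fluorophenyl ring the number stays within the scatter. No measurement here explains this result.

Going by these compounds, it remains open whether the sulfur link would behave alike with a 3,4-dimethoxyphenyl ring, and what a carboxylic acid or a longer chain at this position would do.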